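Solubility notes: ring-isomer swap on the aryl side chain

The source may hold more compounds than are shown below. What is called first, only, known or untested is meant among the compounds shown, and "the series" means these compounds.

Measured in a physicochemical assay for solubility, measured as kinetic solubility; a lower number here means a less soluble compound, a higher number a more soluble compound:
- compound 1, `Cc1cc(C)c(CN2CCc3c(Cl)cc([C@@H](CO)[C@@H]4CCCO4)c(Cl)c3C2=O)c(=O)[nH]1`: compound 1 gives 550000 nM
- compound 2, `COc1cc(C)[nH]c(=O)c1CN1CCc2c(Cl)cc([C@@H](O)C3COC3)c(Cl)c2C1=O`: compound 2 gives 582000 nM
- compound 3, `COC(c1cc(Cl)c2c(c1Cl)C(=O)N(Cc1c(C)cc(C)[nH]c1=O)CC2)C1CCOC1`: compound 3 gives 415000 nM; 457000 nM; 439000 nM; 436000 nM (4 entries)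

Compound 1 holds the lower of the two single-number entries in this assay, but its gap to compound 2 is within the scatter, so no order between the two can be read. Compound 3 is represented by repeated entries, (the several entries of compound 3 in this assay, 415000 nM; 457000 nM; 439000 nM; 436000 nM (4 entries)), which sit close to one another and a little under the other two; the spread of these repeats is a useful picture of how reproducible this assay is for the series.

Compound 4, `Cc1cc(C)c(CN2CCc3c(Cl)cc([C@H](CO)[C@H]4CCOC4)c(Cl)c3C2=O)c(=O)[nH]1`, has not been measured. It has the same atoms as compound 1, joined differently: a group of 8 heavy atoms (6 carbon, 2 oxygen; one five-membered non-aromatic ring with 1 hetero atom) in place of a group of 8 heavy atoms (6 carbon, 2 oxygen; one five-membered non-aromatic ring with 1 hetero atom), on an aromatic carbon. The exchange keeps ring size, hetero-atom count, donor and acceptor count and the number of stereocentres, so no step beyond the scatter is expected in this assay, in either direction. The step from compound 1 to compound 4 is expected to be a 1.1-fold lower number from compound 1 to compound 4 (0.02 log units; within the scatter). The estimate for compound 4 in this assay is 520000 nM, with a range from 300000 nM to 900000 nM.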

Compound 4, solubility: 570000 nM
The estimate for compound 4 lay 1.1-fold (0.04 log units) below the measured number; the measured number falls inside the stated range.
By their numbers in this assay, from the lowest: compounds 1, 4 and 2 (each within the scatter of the next).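

Going by these compounds alone, the pair of compound 1 and compound 4 gives the first step that changes one place only, on an aromatic carbon ortho to a chloro group, and in this assay it reads as a 1.0-fold higher number from compound 1 to compound 4 (0.02 log units; within the scatter). Two groups of the same atoms, each holding one five-membered non-aromatic ring with 1 hetero atom but joined differently, are therefore not told apart at this position by this read-out. The step is no wider than the spread among repeats of a single compound in the same series: the several entries of compound 3 in this assay, 415000 nM; 457000 nM; 439000 nM; 436000 nM (4 entries)

Only an exchange that keeps ring size and hetero-atom count is shown here, so the response at this position to a group of another kind, such as an amine or a carboxylic acid in place of the five-membered ring, remains open. Also open, as far as these compounds go, is whether the same exchange would read alike on another core, such as that of compound 2, and how much of any effect would come from the joining of the ring and how much from the arrangement at the two defined stereocentres.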